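A smaller substituent on the triazole of compound 3

This account rests on a few compounds, and the source may have more. Where it says the series, first, only, none or still open, it means among the compounds named here.

Of the compounds shown here, three sharing one core have been measured in a functional assay on HeLa cells (Homo sapiens) for antiproliferative activity, read by MTT assay, with a stated time of 72 h; on this read-out higher numbers stand for weaker inhibition and lower numbers for stronger inhibition. Compound 1 `O=C1O/C(=C\Cn2cc(-c3cc(F)cc(F)c3)nn2)C(OCc2ccccc2)=C1OCc1ccccc1` gives 17700 nM. Compound 2 `O=C1O[C@H]([C@@H](O)Cn2cc(CNS(=O)(=O)c3ccc(Cl)cc3F)nn2)C(OCc2ccccc2)=C1OCc1ccccc1` gives 20700 nM, and compound 3 `O=C1O[C@H]([C@@H](O)Cn2cc(CCO)nn2)C(OCc2ccccc2)=C1OCc1ccccc1` gives 68800 nM, the highest of the three numbers; the nearest to it is compound 2 and the furthest compound 1, both beyond the scatter. For the measured compounds named here, the only single-point step among them is a 3.3-fold higher number from compound 2 to compound 3 (0.52 log units; beyond the scatter).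

Compound 4 `O=C1O[C@H]([C@@H](O)Cn2ccnn2)C(OCc2ccccc2)=C1OCc1ccccc1` differs from compound 3 by hydrogen in place of 2-hydroxyethyl on an aromatic carbon. Going by the values given here, no measured step removes a substituent from that ring position outright; the one step that bears on it, a 3.3-fold higher number from compound 2 to compound 3 (0.52 log units; beyond the scatter), shows that shrinking the group there weakened inhibition modestly, while compound 1 with an aryl group there gives the lowest number of the three. The expectation for compound 4 is therefore a small step, a 1.1-fold higher number from compound 3 to compound 4 (0.04 log units; within the scatter), possibly within the scatter, with the value estimated at 75000 nM within a range of 25000 nM to 220000 nM.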

Compound 4, half-maximal inhibitory concentration: > 100000 nM
Compound 4: no number, only a limit; the forecaster's own chance of this, stated with the estimate: 25%; at least 1.3-fold (0.12 log units) between middle value and limit.
By their numbers in this assay, from the lowest: compounds 1 and 2 (each within the scatter of the next); then compound 3. At a limit, above all of these: compound 4.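

In this assay, compound 4 gives > 100000 nM, which is a limit of the assay and not a number. Replacing 2-hydroxyethyl with hydrogen on this aromatic carbon gives an at least 1.4-fold higher number from compound 3 to compound 4 (0.16 log units; that floor lies within the scatter), so the data fix only a floor for this change and not its true size, and that floor does not by itself separate the two compounds. The new information is that this position has now been seen carrying only hydrogen, and the compound with that hydrogen is the only one shown that stands at the limit: the limit of > 100000 nM in this assay, at which 1 of the 4 values shown sits.

The compounds shown leave open whether the hydroxyl or the carbons of the 2-hydroxyethyl group matter at this position, a question that an ethyl group there would address. On these data alone, how an amine, a carboxylic acid or a longer chain on this carbon would read also remains open.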